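This account rests on a few compounds, and the source may have more. Where it says the series, first, only, none or still open, it means among the compounds named here.

Compound 1 `CCOC(=O)/C(O)=C/C(=O)c1cn(Cc2cccc(F)c2)c2cccc(OC)c12` gives 63200 nM in an ADME assay on MT4 cells (Homo sapiens) for cytotoxicity, read by MTT assay; on this read-out lower numbers stand for higher toxicity in this test and higher numbers for lower toxicity in this test.
Compound 2 `COc1cccc2c1c(C(=O)/C=C(\O)C(=O)O)cn2Cc1cccc(F)c1` gives 65800 nM in this assay.
Compound 3 `COc1cccc2c1c(C(=O)/C=C(\O)C(=O)O)cn2Cc1c(F)cccc1F` gives 44300 nM in this assay.

Compound 1 sits together with the other two: the step of a 1.0-fold higher number from compound 1 to compound 2 (0.02 log units; within the scatter) is within the scatter, and compound 3, with 44300 nM, also lies within the scatter of compound 1, so the three values are not separable here.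

Compound 4 `CCOC(=O)/C(O)=C/C(=O)c1cn(Cc2ccc(F)c(F)c2F)c2cccc(OC)c12` is not yet measured. It differs from compound 1 by 2,3,4-trifluorophenyl in place of 3-fluorophenyl on a saturated chain carbon bound to an aromatic nitrogen. Within the data shown here, the one measured step that touches this part of the structure is a 1.5-fold lower number from compound 2 to compound 3 (0.17 log units; within the scatter), which stayed within the scatter; the ester-to-acid step a 1.0-fold higher number from compound 1 to compound 2 (0.02 log units; within the scatter) does not bear on the ring. On that basis no step beyond the scatter is expected in this assay, and the estimated step is a 1.3-fold lower number from compound 1 to compound 4 (0.10 log units; within the scatter). Compound 4 is expected at 50000 nM, with a range from 25000 nM to 100000 nM.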

Compound 4, half-maximal cytotoxic concentration: 42700 nM
Compound 4: the middle estimate sits 1.2-fold (0.07 log units) above what was measured; the measured number falls inside the stated range.
By their numbers in this assay, from the lowest: compounds 4, 3, 1 and 2 (each within the scatter of the next).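

With the ester kept, 2,3,4-trifluorophenyl in place of 3-fluorophenyl on a saturated chain carbon bound to an aromatic nitrogen gives a 1.5-fold lower number from compound 1 to compound 4 (0.17 log units; within the scatter) in this assay, so this position has now been varied on the ester as well as on the acid. Across compounds 1 and 4, going from 1 to 3 fluorine atoms on this ring does not separate the two numbers. Nothing available explains this result.

Still open, going by these compounds, is whether a benzyl ring carrying an amine would stay within the scatter of compound 1. The same question applies to a longer chain in place of the benzyl group.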